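The compounds below may be only part of what the source reports. "The series", "measured", "known", "first", "only" and "open" are said of these compounds alone.

Measured so far in a functional assay on CCRF-CEM cells (Homo sapiens) for antiproliferative activity; on this read-out higher numbers stand for weaker inhibition of growth and lower numbers for stronger inhibition of growth:

- Compound 1 `COC(=O)CCCCCCCCCCCCCC/C=C1\CC(CO)(COC(=O)C(C)(C)C)OC1=O` gives 0.691 ug/mL
- Compound 2 `CC(C)(C)C(=O)OCC1(CO)C/C(=C\CCCCCCCCCCCO)C(=O)O1` gives 0.65 ug/mL
- Compound 3 `CC(C)(C)C(=O)OCC1(CO)C/C(=C\CCCCCCCCCCCCCCC=O)C(=O)O1` gives 0.933 ug/mL

These three compounds differ only at the far end of the long chain. Compound 3, at 0.933 ug/mL in this assay, lies within the usual scatter of both other compounds, so the numbers do not separate them. The next compound is compound 4 `CC(C)(C)C(=O)OCCCCCCCCCCCCCCC/C=C1\CC(CO)(COC(=O)C(C)(C)C)OC1=O`. Its change from compound 3 is (((tert-butyl)carbonyl)oxy)methyl in place of formyl on a saturated chain carbon, ten or more bonds along the chain from a double-bonded chain carbon, which puts (((tert-butyl)carbonyl)oxy)methyl in place of formyl on a saturated chain carbon, ten or more bonds along the chain from a double-bonded chain carbon.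

Within the data shown here, three measured steps bear on this change: a 1.1-fold lower number from compound 1 to compound 2 (0.03 log units; within the scatter), a 1.4-fold higher number from compound 1 to compound 3 (0.13 log units; within the scatter) and a 1.4-fold higher number from compound 2 to compound 3 (0.16 log units; within the scatter). All three were changes in this chain and all stayed within the scatter. Among the measured compounds shown here, none of the measured compounds carries the entering group, so the range is kept wide. On these three steps the expected result is a 1.2-fold lower number from compound 3 to compound 4 (0.07 log units; within the scatter) with nothing foreseen beyond the scatter. For compound 4 the estimate is 0.8 ug/mL with an expected range of 0.35 ug/mL to 1.8 ug/mL on this read-out.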

Compound 4, concentration for 50% growth inhibition: > 10 ug/mL
Compound 4: only a limit was reported; the forecaster's own chance of this, stated with the estimate: 3%; middle value at least 12-fold (1.09 log units) away from the limit.
By their numbers in this assay, from the lowest: compounds 2, 1 and 3 (each within the scatter of the next). At a limit, above all of these: compound 4.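

Among these compounds, compound 4 is the first compound here to give a limit of the assay rather than a number, and the limit marks a clear loss of growth inhibition in this assay: the limit of > 10 ug/mL in this assay, at which 1 of the 4 values shown sits. Each new comparison is large: an at least 10-fold higher number from compound 3 to compound 4 (1.03 log units; beyond the scatter), an at least 15-fold higher number from compound 2 to compound 4 (1.18 log units; beyond the scatter) and an at least 14-fold higher number from compound 1 to compound 4 (1.16 log units; beyond the scatter). Among the compounds shown here, the far end of the chain is therefore not indifferent to what it carries, although the hydroxy, formyl and methoxycarbonyl ends of the earlier compounds could not be told apart.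

Going by these compounds, it remains open which part of the entering group matters, the tert-butyl end or the ester link, since compound 1 also ends in an ester and still gives a measured number. On these data alone, how a carboxylic acid or an amine would read at this chain end also remains unknown.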